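A few compounds are considered here, and "the series" means these few. Any claim that something is new, unique, unknown or untested is made for them only; others in the source may bear on it.

Compound 1 `Oc1ccccc1-c1cc(-c2ccc(F)cc2)cc(-c2ccccc2O)n1`; compound 2 `Oc1ccccc1-c1cc(-c2ccccc2C(F)(F)F)cc(-c2ccccc2O)n1`; compound 3 `Oc1ccccc1-c1cc(-c2cccc(C(F)(F)F)c2)cc(-c2ccccc2O)n1`, not yet measured.

In a functional assay on HeLa cells (Homo sapiens) for inhibition (a higher number here means a weaker inhibitor, a lower number a stronger inhibitor), compound 1 gives > 50000 nM, which is a limit of the assay rather than a number. In this assay, for the measured compounds named here, compound 2 gives 5800 nM, the only plain number so far. The step of an at least 8.6-fold lower number from compound 1 to compound 2 (0.93 log units; beyond the scatter) rests on compound 1 reaching only a limit (the limit of > 50000 nM in this assay, at which 1 of the 2 values shown sits). Compound 3 changes compound 2 by 3-(trifluoromethyl)phenyl in place of 2-(trifluoromethyl)phenyl on an aromatic carbon. Going by the values given here, no measured step compares the two trifluoromethyl placements, so the direction is open; a step of modest size at most is expected, a 1.0-fold higher number from compound 2 to compound 3 (0.01 log units; within the scatter). Compound 3 is therefore estimated at 6000 nM, within 1500 nM to 30000 nM.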

Compound 3, half-maximal inhibitory concentration: > 50000 nM
Compound 3 was reported as a limit; the forecaster's own chance of this, stated with the estimate: 20%; middle value at least 8.3-fold (0.92 log units) away from the limit.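

Moving the trifluoromethyl group around its phenyl ring, with no atom gained or lost, matters in this assay: the change gives an at least 8.6-fold higher number from compound 2 to compound 3 (0.93 log units; beyond the scatter). Here the way the same atoms are joined is enough to separate a measurable value from none. Compound 3 reaches only a limit, so its step from compound 1, also a limit, cannot be read: the limit of > 50000 nM in this assay, at which 2 of the 3 values shown sit.

On these data alone, how far compound 3 lies past that limit remains open. So does whether an amine or a carboxylic acid on this phenyl ring, in place of trifluoromethyl, would give a lower number.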